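Swapping Cyclopentyl for Methyl on an Aromatic Oxygen

A few compounds are considered here, and "the series" means these few. Any claim that something is new, unique, unknown or untested is made for them only; others in the source may bear on it.

- Compound 1 `COc1ccccc1OCCNc1ccc(=O)n(Cc2ccc(OC)c(OC3CCCC3)c2)n1`: 28000 nM
- Compound 2 `COc1ccccc1OCCNc1ccc(=O)n(Cc2ccc(OC(F)F)c(OC3CCCC3)c2)n1`: 9100 nM
- Compound 3 `COc1ccc(Cn2nc(NCCOc3ccccc3OC)ccc2=O)cc1OC`: not yet measured

In a functional assay on K562 cells (Homo sapiens) for antiproliferative activity, read by MTT assay, with a stated time of 48 h (on this read-out higher numbers stand for weaker inhibition of growth and lower numbers for stronger inhibition of growth), compound 1 has the higher of the two measured numbers, so it is the weaker growth inhibitor of the pair. Compound 3 differs from compound 1 at one place: methyl in place of cyclopentyl on an oxygen on an aromatic ring. Among the measured compounds shown here, the only measured step, difluoromethyl in place of methyl on an oxygen on an aromatic ring, is a 3.1-fold lower number from compound 1 to compound 2 (0.49 log units; beyond the scatter). That step concerns a different group, so it offers only a rough guide to size and none to direction. No measurement shows cyclopentyl being replaced. A modest shift is therefore expected, leaning tentatively towards a higher number, and it may stay within the scatter. The expected change is a 1.6-fold higher number from compound 1 to compound 3 (0.21 log units; within the scatter). For compound 3 the estimated value is 45000 nM, with an expected range of 15000 nM to 120000 nM.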

Compound 3, concentration for 50% growth inhibition: > 100000 nM
Compound 3: only a limit was reported; the forecaster's own chance of this, stated with the estimate: 20%; middle value at least 2.2-fold (0.34 log units) from the limit.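

In this assay, replacing cyclopentyl with methyl on this oxygen gives an at least 3.5-fold higher number from compound 1 to compound 3 (0.55 log units; beyond the scatter), so growth inhibition weakens. The earlier pair changed only a different group, whereas this result shows that the cyclopentyloxy position also affects the read-out, and that the smaller methoxy does not retain even the weak inhibition of compound 1. For compound 3, > 100000 nM is a limit and not a number, so the full size of the step cannot be stated because of this reading: the limit of > 100000 nM in this assay, at which 1 of the 3 values shown sits.

The compounds shown leave open whether the ring itself matters or whether the number of carbons is enough, which an isopropyl group or a cyclohexyl ring on this oxygen could help separate. They also leave open how a group carrying an amine would behave at this place.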